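The compounds below may be only part of what the source reports. "The series", "measured", "known", "first", "only" and "open" are said of these compounds alone.

Compound 3 `Cc1ncnc2c1c(-c1cc3ccccc3o1)cn2[C@@H]1O[C@H](CO)[C@@H](O)[C@H]1O` gives 19500 nM in a functional assay on K562 cells (Homo sapiens), read by MTT assay, with a stated time of 72 h (a lower number here means a stronger inhibitor, a higher number a weaker inhibitor), the higher of the two numbers in the set; its nearest neighbour, compound 2 `COc1ncnc2c1c(-c1ccsc1)cn2[C@@H]1O[C@H](CO)[C@@H](O)[C@H]1O`, gives 90 nM in this assay. Compound 1 `Cc1ncnc2c1c(-c1cccs1)cn2[C@@H]1O[C@H](CO)[C@@H](O)[C@H]1O` reaches only > 20000 nM in this assay, a limit rather than a number. The change to compound 4 `Cc1ncnc2c1c(-c1ccsc1)cn2[C@@H]1O[C@H](CO)[C@@H](O)[C@H]1O` is thiophen-3-yl in place of 1-benzofuran-2-yl on an aromatic carbon. Within the data shown here, one measured step bears on it: an at least 1.0-fold lower number from compound 1 to compound 3 (0.01 log units; that floor lies within the scatter), which shows no shift beyond the scatter when thiophen-2-yl is replaced by 1-benzofuran-2-yl. Compound 2 shows that a thiophen-3-yl group can sit with a low number, though its core differs from that of compound 4 in one further place. The step of a 2.0-fold lower number from compound 3 to compound 4 (0.29 log units; within the scatter) is therefore expected to be small or modestly downward. Compound 4 is estimated at 10000 nM, between 1500 nM and 40000 nM.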

Compound 4, half-maximal inhibitory concentration: 320 nM
Estimate against measurement, compound 4: 31-fold (1.49 log units) above, and the stated range ends above it.
By their numbers in this assay, from the lowest: compound 2; then compound 4; then compound 3. At a limit, above all of these: compound 1.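

Thiophen-3-yl on this aromatic carbon brings a clear gain over the larger 1-benzofuran-2-yl, with a 61-fold lower number from compound 3 to compound 4 (1.78 log units; beyond the scatter). The attachment point of the thiophene also matters, with thiophen-3-yl in place of thiophen-2-yl giving an at least 62-fold lower number from compound 1 to compound 4 (1.79 log units; beyond the scatter), a floor, as compound 1 carries a limit rather than a number: the limit of > 20000 nM in this assay, at which 1 of the 4 values shown sits.

With thiophen-3-yl held fixed, methyl in place of methoxy gives a 3.6-fold higher number from compound 2 to compound 4 (0.55 log units; beyond the scatter), so the other substituent on the core also counts. Open, from the compounds shown here alone, is how a phenyl group would fare in place of thiophen-3-yl, or an amine in place of methyl or methoxy.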